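The source may report more compounds than this note shows. Statements on the series, on what has been measured and on what is new or still open speak of the compounds shown alone.

Compound 1 `COc1cc(O)c2c(=O)cc(-c3ccc(O)cc3)oc2c1[C@H]1C[C@H](O)[C@H](O)[C@@H](C)O1`: 3160 nM
Compound 2 `COc1cc(O)c2c(=O)cc(-c3ccc(O)cc3)oc2c1[C@H]1CC(=O)[C@H](O)[C@@H](C)O1`: 18400 nM
Compound 3 `C[C@H]1O[C@@H](c2c(O)cc(O)c3c(=O)cc(-c4ccc(O)cc4)oc23)C[C@H](O)[C@@H]1O`: 6350 nM

These three compounds share a core and were tested in a functional assay on MCF7 cells (Homo sapiens) for cytotoxicity, read by resazurin assay, with a stated time of 48 h; on this read-out lower numbers stand for stronger inhibition and higher numbers for weaker inhibition. Among them, compound 3 holds the second highest number; its nearest neighbour is compound 1, whose value is within the scatter of that of compound 3, while compound 2 lies further away with a higher number.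

The step from compound 3 to compound 4 `C[C@H]1O[C@@H](c2c(O)cc(O)c3c(=O)cc(-c4ccc(O)cc4)oc23)C[C@H](O)[C@H]1O` is a change of configuration only: the two compounds have the same atoms and bonds and differ only in configuration as drawn: 1 of 4 stereo elements differ; a stereocentre at a saturated ring carbon is drawn S in compound 3 and R in compound 4. Of the two measured steps, neither involves a change of this kind. The step of a 5.8-fold higher number from compound 1 to compound 2 (0.77 log units; beyond the scatter) swaps one six-membered ring group for another, and the step of a 2.0-fold higher number from compound 1 to compound 3 (0.30 log units; within the scatter) replaces a methyl with hydrogen on an oxygen. Neither tells how the assay responds when a single stereocentre in the saturated ring is inverted with all atoms and bonds kept. For the measured compounds named here, with no comparable step in hand, the expectation in this assay is a change that stays within the scatter, in no particular direction, while allowing a wider range for the unknown.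

On that basis compound 4 is expected to give about 7000 nM, within 2500 nM to 20000 nM, which is estimated as a step of a 1.1-fold higher number from compound 3 to compound 4 (0.04 log units; within the scatter).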

Compound 4, half-maximal inhibitory concentration: 75000 nM
For compound 4 the middle estimate is 11-fold (1.03 log units) below the measured one; measured number outside the range, above it.
By their numbers in this assay, from the lowest: compounds 1 and 3 (each within the scatter of the next); then compound 2; then compound 4.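

In this assay, the inversion at this one saturated ring carbon gives a 12-fold higher number from compound 3 to compound 4 (1.07 log units; beyond the scatter), so the drawn S arrangement in compound 3 goes with much stronger inhibition than the R arrangement in compound 4. The earlier steps shown here all changed atoms, either by swapping one ring group for another or by replacing a methyl with hydrogen on an oxygen, so they could not show that this cytotoxicity read-out responds to spatial arrangement alone. No group enters or leaves here, and the large step can therefore be traced to a single difference, because nothing else separates the pair: the fact that compounds 3 and 4 differ only in the configuration as drawn.

The compounds shown leave open whether the same inversion would have an effect of similar size in compound 1, which carries the methyl on the aromatic oxygen, or in compound 2, which carries a carbonyl in the saturated ring. They also leave open what an amine on this same ring carbon would do in either configuration, and whether the preference for the S arrangement would hold with such a group in place.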